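This account rests on a few compounds, and the source may have more. Where it says the series, first, only, none or still open, it means among the compounds named here.

Measured so far:
- compound 1 `COCCNS(=O)(=O)c1ccc(C)c(C#Cc2cc(Cl)ccc2OCC(=O)O)c1`: 3.6 nM in an assay on CHO cells for displacement of a labelled ligand from prostaglandin D2 receptor 2 (Homo sapiens), read by scintillation counting; a lower number here means a stronger inhibitor, a higher number a weaker inhibitor
- compound 2 `Cc1ncc(S(=O)(=O)N(C)C)cc1C#Cc1cc(Cl)ccc1OCC(=O)O`: 41 nM in this assay

Of these two numbers, compound 1 carries the lower one, and compound 2 sits at a higher value that lies beyond the scatter of the measurement. Among the measured compounds shown here, no single-point step between the measured compounds is available, so the account rests on compound 1 alone.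

Compound 3 `Cc1ccc(S(=O)(=O)N(C)CC(C)C)cc1C#Cc1cc(Cl)ccc1OCC(=O)O` has not yet been measured. It differs from compound 1 in one place: isobutyl(methyl)amino in place of (2-methoxyethyl)amino on a sulfonyl sulfur. The shared core, the alkyne link and the acid-bearing ring are kept unchanged.

For this assay a step from compound 1 to compound 3 of the size a 1.7-fold higher number from compound 1 to compound 3 (0.22 log units; within the scatter) is expected, that is, a modest move toward a higher number, close to the edge of the scatter. Compound 3 is accordingly estimated at 6 nM, with a plausible range from 1.5 nM to 25 nM.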

Compound 3, inhibition constant: 4.2 nM
Estimate against measurement, compound 3: 1.4-fold (0.15 log units) above, within the range that was stated.
By their numbers in this assay, from the lowest: compounds 1 and 3 (each within the scatter of the next); then compound 2.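

In this assay, putting isobutyl(methyl)amino in place of (2-methoxyethyl)amino on a sulfonyl sulfur gives a 1.2-fold higher number from compound 1 to compound 3 (0.07 log units; within the scatter), so the two compounds cannot be told apart. The entering group has no hydrogen-bond donor or acceptor, whereas the leaving group has one of each, and this pair shows that such a swap at this place can leave the number within the scatter. Nothing measured on these compounds explains this result.

This single swap changes the chain and the substitution on the nitrogen together, so isobutylamino would be needed to separate the two changes. As far as these compounds go, it also remains open whether a ring such as morpholine, or a chain ending in an amine or a carboxylic acid, would be accommodated on the sulfonyl sulfur as well.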